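The source may report more compounds than this note shows. Statements on the series, on what has been measured and on what is new or still open speak of the compounds shown alone.

Working notes on the series. In a functional assay on HepG2 cells (Homo sapiens) for cytotoxicity, read by MTT assay, with a stated time of 48 h (a lower number here means a stronger inhibitor, a higher number a weaker inhibitor), compound 1 `CC(C)COc1ccc2c(Cl)ccnc2c1` gives 2250 nM, compound 2 `CCCCCCOc1ccc2c(Cl)ccnc2c1` gives 2420 nM, and compound 3 `Clc1ccnc2cc(OCc3ccccc3)ccc12` gives 2680 nM. The three numbers sit close together: the step of a 1.1-fold higher number from compound 1 to compound 2 (0.03 log units; within the scatter), the step of a 1.2-fold higher number from compound 1 to compound 3 (0.08 log units; within the scatter) and the step of a 1.1-fold higher number from compound 2 to compound 3 (0.04 log units; within the scatter) all stay within the scatter, so compound 3 cannot be told apart from compound 1 or compound 2 on these numbers.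

Compound 4 `CCOc1ccc2c(Cl)ccnc2c1` differs from compound 3 by methyl in place of phenyl on a saturated chain carbon bound to an oxygen on an aromatic ring. Going by the values given here, the steps that bear on it are the two that exchange the group at the same place: from compound 1 to compound 3 and from compound 2 to compound 3, both within the scatter, so exchanging isopropyl, pentyl or phenyl there has not moved this assay. The exchange of phenyl for methyl is therefore expected to give no step beyond the scatter, in either direction.

Compound 4 is expected to give about 2500 nM in this assay, with a range of 1200 nM to 5200 nM. The step from compound 3 to compound 4 is thus estimated as a 1.1-fold lower number from compound 3 to compound 4 (0.03 log units; within the scatter).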

Compound 4, half-maximal inhibitory concentration: 2660 nM
The estimate for compound 4 lay 1.1-fold (0.03 log units) below the measured number; the measured number falls inside the stated range.
By their numbers in this assay, from the lowest: compounds 1, 2, 4 and 3 (each within the scatter of the next).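

The step of a 1.0-fold lower number from compound 3 to compound 4 (0.00 log units; within the scatter) shows that, in this assay, the aromatic ring of the phenyl group is not required on this saturated chain carbon bound to an oxygen on an aromatic ring, since methyl takes its place without a step beyond the scatter. The small end of the series reads the same way, with a 1.1-fold higher number from compound 2 to compound 4 (0.04 log units; within the scatter) for hydrogen in place of butyl and a 1.2-fold higher number from compound 1 to compound 4 (0.07 log units; within the scatter) for methyl in place of isopropyl, so all four compounds now stand within the scatter of one another. No measurement is available that would explain this flat reading.

From the compounds shown here alone, whether an amine or a carboxylic acid at this place would move the number remains open. The four compounds also leave open whether any change to the shared core would give a step beyond the scatter.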